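From pyridin-4-yl to pyridin-3-yl: compound 4 in prospect

This account rests on a few compounds, and the source may have more. Where it says the series, first, only, none or still open, it means among the compounds named here.

Going by the values given here, in an ADME assay on microsomes from liver (Homo sapiens) for metabolic stability, read by LC-MS, with a stated time of 30 min, tested at 0.5 uM (a lower number here means that less of the compound is left, a higher number that more of the compound is left), compound 3 (`c1cc(-c2nc(-c3csc(N=C4NCCCN4)n3)cs2)ccn1`) gives 58%, the lowest of the three numbers so far. Compound 1 (`c1ccc(-c2nc(-c3csc(N=C4NCCCN4)n3)cs2)cc1`) gives 83% and compound 2 (`Oc1ccc(-c2nc(-c3csc(N=C4NCCCN4)n3)cs2)cc1`) gives 86%, and the hydroxy group makes little difference, with a number 3 percentage points higher from compound 1 to compound 2 (within the scatter). Replacing phenyl with pyridin-4-yl gave a number 25 percentage points lower from compound 1 to compound 3 (beyond the scatter), while replacing 4-hydroxyphenyl with pyridin-4-yl gave a number 28 percentage points lower from compound 2 to compound 3 (beyond the scatter).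

Compound 4 (`c1cncc(-c2nc(-c3csc(N=C4NCCCN4)n3)cs2)c1`) has not yet been measured. It carries pyridin-3-yl in place of pyridin-4-yl on an aromatic carbon. Among the compounds with values here, no measured compound carries pyridin-3-yl, so this change has no direct precedent. The two ring replacements above are the closest evidence, and they show how far a change at this place has moved the number. Since compound 4 keeps a pyridine ring, a smaller move than those is expected, and the estimated step is a number 5 percentage points higher from compound 3 to compound 4 (within the scatter). For compound 4 the estimate is 63%, with an expected range from 45% to 80%.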

Compound 4, percent of the compound remaining: 78%
Compound 4: the middle estimate sits 15 percentage points below what was measured; the measured number falls inside the stated range.
By their numbers in this assay, from the lowest: compound 3; then compounds 4, 1 and 2 (each within the scatter of the next).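

In this assay, shifting the pyridine nitrogen alone, with the same atoms and the same counts of donors and acceptors, gives a number 20 percentage points higher from compound 3 to compound 4 (beyond the scatter) at this place on the five-membered ring, so where the nitrogen sits matters as well as whether the ring holds one. The lower number of compound 3 is therefore not shared by both pyridines, since the steps of a number 5 percentage points lower from compound 1 to compound 4 (within the scatter) and a number 8 percentage points lower from compound 2 to compound 4 (within the scatter) leave pyridin-3-yl level with phenyl and 4-hydroxyphenyl. Nothing measured here accounts for the gap between the two pyridines.

From the compounds shown here alone, whether pyridin-2-yl would group with compound 3 or with compound 4 remains open. So does the effect of an amine or a methoxy group on the pyridin-3-yl ring.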